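Amino for Chloro on a Fused Core in Glioma Cells

This account rests on a few compounds, and the source may have more. Where it says the series, first, only, none or still open, it means among the compounds named here.

Compound 1 `Nc1nc(Cl)c2ncn(Cc3ccc(CCl)cc3)c2n1`: 44700 nM
Compound 2 `ClCc1cccc(Cn2cnc3c(Cl)nc(Cl)nc32)c1`: 5620 nM
Compound 3 `ClCc1ccc(Cn2cnc3c(Cl)nc(Cl)nc32)cc1`: 7410 nM

All three were tested in a functional assay on U-251 cells (Homo sapiens) for cytotoxicity, read by sulforhodamine B assay, with a stated time of 48 h; on this read-out lower numbers stand for higher toxicity in this test and higher numbers for lower toxicity in this test. Compound 2 and compound 3 share the same atoms joined differently; the difference between the two cores is not broken down here, and their values lie within the scatter of each other. Compound 1 differs from compound 3 by one change, (amino in place of chloro on an aromatic carbon), which gave a 6.0-fold higher number from compound 3 to compound 1 (0.78 log units; beyond the scatter). Compound 4 `Nc1nc(Cl)c2ncn(Cc3cccc(CCl)c3)c2n1` is not yet measured; it differs from compound 2 by amino in place of chloro on an aromatic carbon, the same change. The step from compound 2 to compound 4 is therefore expected to be about a 5.9-fold higher number from compound 2 to compound 4 (0.77 log units; beyond the scatter), because the same change gave a 6.0-fold higher number from compound 3 to compound 1 (0.78 log units; beyond the scatter). Compound 4 is estimated at 33000 nM in this assay, expected between 14000 nM and 75000 nM.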

Compound 4, concentration lethal to 50% of the cells: 9330 nM
The estimate for compound 4 lay 3.5-fold (0.55 log units) above the measured number; the whole stated range lies above it.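

In this assay, amino in place of chloro on an aromatic carbon gave a 1.7-fold higher number from compound 2 to compound 4 (0.22 log units; within the scatter), a step that stays within the scatter. The size of the step did not carry over from one core to the other: the same change on two cores in this assay, a 6.0-fold higher number (0.78 log units; beyond the scatter) from compound 3 to compound 1 and a 1.7-fold higher number (0.22 log units; within the scatter) from compound 2 to compound 4, 3.6-fold (0.56 log units) apart, beyond the scatter of two such steps. In these two pairs, then, the step differs with the core, but two pairs do not show why they differ or what the change would do on any further core.

The compounds shown leave open how a methoxy group or a longer amine in place of the same chloro would read in this assay. They also leave open whether the two steps would stay apart in another cell line.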